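Dropping the Trifluoromethyl Group on the Aryl Ring

The source may report more compounds than this note shows. Statements on the series, on what has been measured and on what is new or still open speak of the compounds shown alone.

Compound 2 `CN1CCN(c2nc(-c3ccc(Cl)c(C(F)(F)F)c3)nc3[nH]cnc23)CC1` stands highest of the three numbers in an assay on cells for displacement of a labelled ligand from adenosine receptor A3 (Homo sapiens), read by scintillation counting and radioligand binding, with a stated time of 180 min (on this read-out lower numbers stand for stronger inhibition and higher numbers for weaker inhibition), giving 794 nM. Compound 3 `Oc1cccc(-c2nc(N3CCCCC3)c3nc[nH]c3n2)c1` gives 63.1 nM, and compound 1 `CN1CCN(c2nc(-c3ccc(Cl)c(Cl)c3)nc3[nH]cnc23)CC1` gives 39.8 nM. Going by the values given here, the one measured step that bears on the new change is a 20-fold higher number from compound 1 to compound 2 (1.30 log units; beyond the scatter), a trifluoromethyl in place of chloro on an aromatic carbon. Compound 4 `CN1CCN(c2nc(-c3ccc(Cl)cc3)nc3[nH]cnc23)CC1` carries the reverse direction of removal: hydrogen in place of trifluoromethyl on an aromatic carbon. Since compound 2 was weakened sharply by the step of a 20-fold higher number from compound 1 to compound 2 (1.30 log units; beyond the scatter), removing that trifluoromethyl is expected to lower the number again, though whether hydrogen restores the level of compound 1 is not known. Compound 4 is therefore expected to reach about 80 nM, with a range from 25 nM to 250 nM, a step of a 9.9-fold lower number from compound 2 to compound 4 (1.00 log units; beyond the scatter).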

Compound 4, inhibition constant: 39.8 nM
Beside the measured number, compound 4's estimate is 2.0-fold (0.30 log units) above it; low and high end bracket the measured number.
By their numbers in this assay, from the lowest: compounds 1, 4 and 3 (each within the scatter of the next); then compound 2.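

In this assay, taking the trifluoromethyl group away gives a 20-fold lower number from compound 2 to compound 4 (1.30 log units; beyond the scatter) and so fully reverses the earlier loss. Hydrogen and chloro cannot be told apart at this carbon, with no change at the digits printed from compound 1 to compound 4 (within the scatter), so among these three groups only trifluoromethyl stands out, and compound 1 gains nothing measurable from its second chloro group. No measurement offered here accounts for the trifluoromethyl penalty. On these data alone, whether methyl, methoxy or an amine at this carbon would match hydrogen or trifluoromethyl remains open, as does what the remaining chloro group of compound 4 contributes.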